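Compound 3 and the Group on the Carbonyl Carbon

The compounds below may be only part of what the source reports. "The series", "measured", "known", "first", "only" and "open" are said of these compounds alone.

Measured in a functional assay on liver (Rattus norvegicus, strain Sprague-Dawley) for inhibition, with a stated time of 1 h; a lower number here means a stronger inhibitor, a higher number a weaker inhibitor:
compound 1 `COc1cc(C2Oc3cc([C@H]4Oc5cc(O)cc(O)c5C(=O)[C@@H]4O)ccc3OC2COC(=O)c2cc([N+](=O)[O-])cc([N+](=O)[O-])c2)ccc1O`: 14600 nM
compound 2 `COc1cc(C2Oc3cc([C@H]4Oc5cc(O)cc(O)c5C(=O)[C@@H]4O)ccc3OC2COC(=O)/C=C/c2ccc(Cl)cc2)ccc1O`: 12000 nM

Among the compounds with values here, compound 2, at 12000 nM, stands within the scatter of compound 1, the only other measured compound, so the two cannot be ranked. Compound 3 `COc1cc(C2Oc3cc([C@H]4Oc5cc(O)cc(O)c5C(=O)[C@@H]4O)ccc3OC2COC(=O)c2ccc(OC)c(OC)c2)ccc1O` has not yet been measured. It carries 3,4-dimethoxyphenyl in place of 2-(4-chlorophenyl)ethenyl on a carbonyl carbon. Within the data shown here, only one measured step bears on this change, and it exchanged groups at the same carbonyl carbon: a 1.2-fold lower number from compound 1 to compound 2 (0.09 log units; within the scatter), which lies within the scatter. Among the measured compounds shown here, one step is a thin guide, and the data hold no earlier example of this exact exchange. For the measured compounds named here, with that step as the sole evidence, no change beyond the scatter is expected in this assay, in either direction. The expected step is a 1.1-fold higher number from compound 2 to compound 3 (0.03 log units; within the scatter). For compound 3 the estimate is 13000 nM, with an expected range from 6000 nM to 28000 nM.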

Compound 3, half-maximal inhibitory concentration: 16000 nM
For compound 3 the middle estimate is 1.2-fold (0.09 log units) below the measured one, and the stated range covers the measured number.
By their numbers in this assay, from the lowest: compounds 2, 1 and 3 (each within the scatter of the next).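

In this assay the change to 3,4-dimethoxyphenyl on this carbonyl carbon gives a 1.3-fold higher number from compound 2 to compound 3 (0.12 log units; within the scatter) and a 1.1-fold higher number from compound 1 to compound 3 (0.04 log units; within the scatter) and so leaves compound 3 within the scatter of both earlier compounds. Within the data shown here, three different groups at this place now cannot be told apart, where the earlier compounds offered only two. The exchange also replaces 2-(4-chlorophenyl)ethenyl, with 0 hydrogen-bond acceptors, by 3,4-dimethoxyphenyl, with 2 hydrogen-bond acceptors, and the number still stays within the scatter. Nothing at hand explains why these groups read alike.

Going by these compounds, all three groups carry a six-membered aromatic ring of carbon, so it remains open whether an amine, a carboxylic acid or a plain alkyl chain on this carbonyl carbon would move the number beyond the scatter.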